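Methoxy to hydroxy on compound 2: working notes

A few compounds are considered here, and "the series" means these few. Any claim that something is new, unique, unknown or untested is made for them only; others in the source may bear on it.

Measured so far in a functional assay on MCF7 cells (Homo sapiens) for cytotoxicity, read by MTT assay, with a stated time of 6 days; a lower number here means that less compound is needed, a higher number that more compound is needed for the effect (both entries are limits, not numbers):
- compound 1 `COC(=O)c1c(-c2ccc(O)cc2)oc2ccccc2c1=O` gives the limit > 25 ug/mL (no number reported)
- compound 2 `COc1cc(-c2cc(=O)c3cc(O)ccc3o2)cc(OC)c1OC` gives the limit > 25 ug/mL (no number reported)

Among the compounds with values here, compound 2 has only a limit and no number in this assay (the same holds for the only other measured compound). The picture so far is the limit of > 25 ug/mL in this assay, at which 2 of the 2 values shown sit, and nothing more, so the two compounds cannot be put in any order.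

Compound 3 `COc1cc(-c2cc(=O)c3cc(O)ccc3o2)cc(OC)c1O` differs from compound 2 in one place (hydrogen in place of methyl on an oxygen on an aromatic ring), methoxy to hydroxy, with hydrogen in place of methyl on an oxygen on an aromatic ring.

Within the data shown here, no measured step between two compounds is available for this change, and the data give no direct size for it. Among the measured compounds shown here, no step beyond the usual scatter is expected in this assay (and no clear direction either), an expectation resting only on the limit of > 25 ug/mL in this assay, at which 2 of the 2 values shown sit, as the sole evidence. The expected step is a step that the limit leaves unreadable from compound 2 to compound 3 (an estimate against a limit, so a rough one). For compound 3 the estimated value is 30 ug/mL (expected range 12 ug/mL to 60 ug/mL), and a limit in place of a number is the likelier report.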

Compound 3, concentration for half-maximal effect: > 25 ug/mL
Compound 3 ended at the assay's limit; the forecaster's own chance of this, stated with the estimate: 75%; the middle value lies beyond the limit too.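

Compound 2 and compound 3 both carry only a limit, and no step can be read between them for the change from methoxy to hydroxy. The compounds shown leave open what number any of them would give, and whether hydrogen in place of methyl on this oxygen shifts the value at all.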